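A few compounds are considered here, and "the series" means these few. Any claim that something is new, unique, unknown or untested is made for them only; others in the source may bear on it.

Three compounds sharing one core, which differ in the group on one ether oxygen, have been measured in a functional assay on MCF7 cells (Homo sapiens) for inhibition, read by MTT assay, with a stated time of 3 days; a lower number here means a stronger inhibitor, a higher number a weaker inhibitor. Compound 1 `C/C=C/COc1cc(/C=C\c2cc(OC)c(OC)c(OC)c2)ccc1OC` gives 5400 nM, compound 2 `COc1ccc(/C=C\c2cc(OC)c(OC)c(OC)c2)cc1OCc1ccc(Br)cc1` gives 29000 nM, and compound 3 `COc1ccccc1/C=C/CCCOc1cc(/C=C\c2cc(OC)c(OC)c(OC)c2)ccc1OC` gives 21000 nM. Compound 3 therefore sits at the weaker end of this small set. The gap to its nearest neighbour is small, a 1.4-fold lower number from compound 2 to compound 3 (0.14 log units; within the scatter). The gap on its other side is larger, a 3.9-fold higher number from compound 1 to compound 3 (0.59 log units; beyond the scatter), and a similar gap appears in a 5.4-fold higher number from compound 1 to compound 2 (0.73 log units; beyond the scatter).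

The next compound, compound 4 `COc1ccc(/C=C/CCCOc2cc(/C=C\c3cc(OC)c(OC)c(OC)c3)ccc2OC)cc1`, departs from compound 3 in a single group: 4-methoxyphenyl in place of 2-methoxyphenyl on a double-bonded chain carbon bound to a double-bonded chain carbon. The two have the same atoms, joined differently. Within the data shown here, no measured step moves a methoxy group around a ring, so none tests this change directly. The measured steps exchange whole groups, and even the large exchange of 4-bromophenyl for 4-(2-methoxyphenyl)but-3-en-1-yl stayed small, a 1.4-fold lower number from compound 2 to compound 3 (0.14 log units; within the scatter). In this assay, no step beyond the scatter is therefore expected, and the estimated step is a 1.1-fold lower number from compound 3 to compound 4 (0.02 log units; within the scatter). Compound 4 is estimated at 20000 nM, with an expected range of 8000 nM to 50000 nM.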

Compound 4, half-maximal inhibitory concentration: 16000 nM
The estimate for compound 4 lay 1.3-fold (0.10 log units) above the measured number, within the range that was stated.
By their numbers in this assay, from the lowest: compound 1; then compounds 4, 3 and 2 (each within the scatter of the next).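

In this assay the exchange of 2-methoxyphenyl for 4-methoxyphenyl, on a double-bonded chain carbon bound to a double-bonded chain carbon, gives the first direct test of this change, and the result of a 1.3-fold lower number from compound 3 to compound 4 (0.12 log units; within the scatter) does not separate the two isomers. The 4-(4-methoxyphenyl)but-3-en-1-yl group also keeps the standing of its isomer among the other ether groups: the exchange for 4-bromophenyl gives a 1.8-fold lower number from compound 2 to compound 4 (0.26 log units; within the scatter) and does not separate those two compounds, whereas the exchange for prop-1-en-1-yl gives a 3.0-fold higher number from compound 1 to compound 4 (0.47 log units; beyond the scatter) and leaves compound 1 with the lowest number of the four. No measurement is available that would explain these results or connect them to any property of the groups.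

Going by these compounds, it remains open whether a more different group on this ring, such as a hydroxyl, an amine or a carboxylic acid in place of the methoxy group, would produce a step beyond the scatter. On these data alone, it is also open whether the two methoxyphenyl isomers would stay this close on a shorter or longer chain.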